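Acetyl for dimethylamino on the aryl of compound 1

A few compounds are considered here, and "the series" means these few. Any claim that something is new, unique, unknown or untested is made for them only; others in the source may bear on it.

Measured so far:
compound 1, `COc1cc(C)cc(-c2c(-c3ccnc(-c4ccc(N(C)C)cc4)c3)cnn2CC#N)c1`: 85.3 nM in a functional assay on 786-0 cells (Homo sapiens) for inhibition, read by sulforhodamine B assay, with a stated time of 48 h; on this read-out higher numbers stand for weaker inhibition of growth and lower numbers for stronger inhibition of growth
compound 2, `Cc1cc(O)cc(-c2nn(CC#N)cc2-c2ccnc(-c3ccc(Oc4ccccc4)cc3)c2)c1`: 2140 nM in this assay

Compound 1 holds the lowest number of the two in this assay; compound 2 sits a good way above it, well beyond the scatter. Going by the values given here, the two compounds differ in several places at once, so their values show only that the pair spans a wide range, and no single step can be read from them.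

The next compound is compound 3, `COc1cc(C)cc(-c2c(-c3ccnc(-c4ccc(C(C)=O)cc4)c3)cnn2CC#N)c1`. It differs from compound 1 in one place only: acetyl in place of dimethylamino on an aromatic carbon.

Among the compounds with values here, no measured pair shows this kind of change, so there is nothing to anchor its size. The expectation is for a moderate move towards a higher number in this assay, that is, a step from compound 1 to compound 3 of a 2.9-fold higher number from compound 1 to compound 3 (0.47 log units; beyond the scatter), with a real chance that the step stays within the scatter. On that basis compound 3 is estimated at 250 nM, with a range of 60 nM to 1000 nM.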

Compound 3, concentration for 50% growth inhibition: 3110 nM
The estimate for compound 3 lay 12-fold (1.09 log units) below the measured number; the whole stated range lies below it.
By their numbers in this assay, from the lowest: compound 1; then compounds 2 and 3 (each within the scatter of the next).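

In this assay, the change from 4-(dimethylamino)phenyl to 4-acetylphenyl gives a 36-fold higher number from compound 1 to compound 3 (1.56 log units; beyond the scatter), so this position is highly sensitive to the group it carries. The size of the step is notable. The two groups match in heavy-atom count, hydrogen-bond donors and acceptors, and net charge, and neither adds a ring. Those counts therefore do not separate the groups; what does differ is one nitrogen for one oxygen and the double bond outside aromatic rings that enters with acetyl. Nothing measured here bears on what lies behind the step.

Still open, from the compounds shown here alone, is whether the low number of compound 1 depends on dimethylamino itself, which a methylamino, morpholine or methoxy group at the same place would help to test. Also open, going by these compounds, are whether a carboxylic acid or primary amide would stay close to acetyl, and whether a step of this size would recur with other groups elsewhere on the shared core.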